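Replacing the Amide Link with a Sulfonamide: Expected Potency

A few compounds are considered here, and "the series" means these few. Any claim that something is new, unique, unknown or untested is made for them only; others in the source may bear on it.

Three compounds have been measured in a functional assay on 143B cells (Homo sapiens) for antiproliferative activity, read by MTT assay, with a stated time of 48 h; a lower number here means a stronger inhibitor, a higher number a weaker inhibitor:

Compound 1 `O=C(Nc1cccc(/C=C/C(=O)c2nc3ccccc3[nH]2)c1)c1ccc(Cl)cc1`: 7440 nM
Compound 2 `Cc1cccc(C(=O)Nc2cccc(/C=C/C(=O)c3nc4ccccc4[nH]3)c2)c1`: 4880 nM
Compound 3 `O=C(Nc1cccc(/C=C/C(=O)c2nc3ccccc3[nH]2)c1)c1cccc(C(F)(F)F)c1`: 9570 nM

All three share a core and differ only in the aryl group on the carbonyl carbon of the amide. Within the data shown here, compound 2 sits at the low end of the three numbers, but this means little: a 1.5-fold lower number from compound 1 to compound 2 (0.18 log units; within the scatter), a 2.0-fold higher number from compound 2 to compound 3 (0.29 log units; within the scatter) and a 1.3-fold higher number from compound 1 to compound 3 (0.11 log units; within the scatter) are all within the scatter, so the three behave as equals, and no compound can be called the most active.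

Compound 4 `Cc1ccccc1S(=O)(=O)Nc1cccc(/C=C/C(=O)c2nc3ccccc3[nH]2)c1` changes something different: (2-methylphenyl)sulfonyl in place of (3-methylphenyl)carbonyl on a nitrogen on an aromatic ring. Among the measured compounds shown here, none of the measured steps touches this link; they only vary the aryl ring and show that such variation leaves the number essentially unchanged. The move to a sulfonyl group is a larger structural change than any measured step, so there is no direct guide. The expectation for compound 4 is therefore a step of a 1.3-fold higher number from compound 2 to compound 4 (0.12 log units; within the scatter), likely not beyond the scatter, with a wide range. Compound 4 is estimated at 6500 nM, between 2500 nM and 17000 nM.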

Compound 4, half-maximal inhibitory concentration: 4060 nM
Compound 4: the middle estimate sits 1.6-fold (0.20 log units) above what was measured; low and high end bracket the measured number.
By their numbers in this assay, from the lowest: compounds 4, 2, 1 and 3 (each within the scatter of the next, the first and the last beyond it).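

In this assay, putting (2-methylphenyl)sulfonyl on the nitrogen in place of (3-methylphenyl)carbonyl gives a 1.2-fold lower number from compound 2 to compound 4 (0.08 log units; within the scatter), and putting it in place of (4-chlorophenyl)carbonyl gives a 1.8-fold lower number from compound 1 to compound 4 (0.26 log units; within the scatter). The earlier compounds shown here varied only the aryl ring, whereas these steps show that the carbonyl of the link can also be exchanged for a sulfonyl without a step beyond the scatter. No measurement at hand speaks to why the numbers stay so close.

The compounds shown leave open how much of the step belongs to the sulfonyl and how much to the methyl group, which sits in 3-methylphenyl on one side and 2-methylphenyl on the other. Also open, going by these compounds, is what happens with a simple alkyl chain on the sulfonyl in place of the aryl ring, or with an amine or a carboxylic acid on that ring.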